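The compounds below may be only part of what the source reports. "The series", "measured", "known", "first", "only" and "open" are said of these compounds alone.

In an ADME assay on microsomes from liver (Homo sapiens) for metabolic stability, read by LC-MS, tested at 1 uM (a higher number here means faster removal of the compound, a lower number slower removal), compound 1 `c1cc([C@H]2CC[C@]3(CC2)OOC2(O3)C3CC4CC(C3)CC2C4)ccc1OCCCNC1CCOCC1` gives 10 mL.min-1.g-1 and compound 2 `CC(C)(O)CN1CCC(Oc2ccc([C@H]3CC[C@]4(CC3)OOC3(O4)C4CC5CC(C4)CC3C5)cc2)CC1` gives 18 mL.min-1.g-1. These two values lie within the scatter of each other, with a 1.8-fold higher number from compound 1 to compound 2 (0.26 log units; within the scatter). Compound 3 `c1cc([C@H]2CC[C@]3(CC2)OOC2(O3)C3CC4CC(C3)CC2C4)ccc1OCCC1CCNCC1` gives < 7 mL.min-1.g-1, which is a limit of the assay and not a number. Its position is therefore known only from that limit, and the steps reaching it are an at least 1.4-fold lower number from compound 1 to compound 3 (0.15 log units; that floor lies within the scatter) and an at least 2.5-fold lower number from compound 2 to compound 3 (0.41 log units; beyond the scatter).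

Compound 4 `CC(C)(CN)Oc1ccc([C@H]2CC[C@]3(CC2)OOC2(O3)C3CC4CC(C3)CC2C4)cc1` carries 1-(aminomethyl)-1-methylethyl in place of 2-(piperidin-4-yl)ethyl on an oxygen on an aromatic ring. Among the measured compounds shown here, the entering group has no ring, and no measured compound carries it, so no measured step covers this exact change. The nearest evidence is the three steps above, all of which alter the side chain on that oxygen. For the measured compounds named here, only the step to compound 3 from compound 2 goes beyond the scatter, and the span from compound 1 to compound 2 stays within it.

In this assay the expected result is no step beyond the scatter, with an at least 1.1-fold higher number from compound 3 to compound 4 (0.05 log units; that floor lies within the scatter) as the estimated step. A reading at the limit is also expected to be quite possible. For compound 4 the estimated value is 8 mL.min-1.g-1, with an expected range of 4 mL.min-1.g-1 to 16 mL.min-1.g-1.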

Compound 4, intrinsic clearance in microsomes: < 7 mL.min-1.g-1
Compound 4: a limit, no number; the forecaster's own chance of this, stated with the estimate: 45%; at least 1.1-fold (0.05 log units) between middle value and limit.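

On an oxygen on an aromatic ring, the open-chain 1-(aminomethyl)-1-methylethyl now joins 2-(piperidin-4-yl)ethyl at the limit in this assay, so a reading there does not need a ring in this side chain. Two steps can be read, an at least 2.5-fold lower number from compound 2 to compound 4 (0.41 log units; beyond the scatter) and an at least 1.4-fold lower number from compound 1 to compound 4 (0.15 log units; that floor lies within the scatter): only the first shows a separation beyond the scatter, so 1-(2-hydroxy-2-methylpropyl)piperidin-4-yl is the one side chain shown to stand apart from the new group, while no order can be given against 3-((oxan-4-yl)amino)propyl. Compound 3 and compound 4 both rest on a limit of the assay, so the step between them cannot be read and the smaller side chain cannot be ranked against the larger one: the limit of < 7 mL.min-1.g-1 in this assay, at which 2 of the 4 values shown sit.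

On these data alone, the true values of compound 3 and compound 4 remain open, and with them any difference between the two side chains. Also open, as far as these compounds go, is whether the amine of 1-(aminomethyl)-1-methylethyl matters for this reading, which a carboxylic acid or an amide at that end of the chain, or a longer chain carrying the same amine, would test.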